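Hydrazide on a saturated linker replaces cyclopropylamide

The source may hold more compounds than are shown below. What is called first, only, known or untested is meant among the compounds shown, and "the series" means these compounds.

Measured so far:
Compound 1 `CNC(=O)/C=C/c1ccncc1-c1ccc2ccccc2c1`: 6550 nM
Compound 2 `COC(=O)/C=C/c1ccncc1-c1ccc2ccccc2c1`: 350 nM
Compound 3 `O=C(/C=C/c1ccncc1-c1ccc2ccccc2c1)NC1CC1`: 6180 nM

In a functional assay on HCT-116 cells (Homo sapiens) for inhibition, read by MTT assay, with a stated time of 72 h (a higher number here means a weaker inhibitor of growth, a lower number a stronger inhibitor of growth), compound 3 gives the second highest of the three numbers; compound 1 sits within the scatter of it, while compound 2 lies far lower, shown by an 18-fold higher number from compound 2 to compound 3 (1.25 log units; beyond the scatter). Compound 4 `NNC(=O)CCc1ccncc1-c1ccc2ccccc2c1` arises from compound 3 by the change (2-(aminocarbamoyl)ethyl in place of 2-(cyclopropylcarbamoyl)ethenyl on an aromatic carbon). Among the compounds with values here, two measured steps bear on it: a 1.1-fold lower number from compound 1 to compound 3 (0.03 log units; within the scatter) shows that swapping the group on the amide-type nitrogen changes little, and a 19-fold lower number from compound 1 to compound 2 (1.27 log units; beyond the scatter) shows that only the ester departs from the amide-type pattern. Going by these compounds, compound 4 keeps an amide-type carbonyl, so a step near zero is expected, a 1.3-fold higher number from compound 3 to compound 4 (0.11 log units; within the scatter); removing the double bond is untested, widening the range. Compound 4 is estimated at 8000 nM, between 2500 nM and 25000 nM.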

Compound 4, concentration for 50% growth inhibition: > 30000 nM
Compound 4: no number, only a limit; the forecaster's own chance of this, stated with the estimate: 15%; at least 3.7-fold (0.57 log units) between middle value and limit.
By their numbers in this assay, from the lowest: compound 2; then compounds 3 and 1 (each within the scatter of the next). At a limit, above all of these: compound 4.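

In this assay compound 4 gives no number, only a limit of the assay: the limit of > 30000 nM in this assay, at which 1 of the 4 values shown sits. The earlier swap on the amide-type nitrogen stayed within the scatter, but this change at the same position gives an at least 4.8-fold higher number from compound 3 to compound 4 (0.68 log units; beyond the scatter) and an at least 4.5-fold higher number from compound 1 to compound 4 (0.66 log units; beyond the scatter), so keeping an amide-type carbonyl does not by itself hold the activity. Against the ester, the gap is an at least 85-fold higher number from compound 2 to compound 4 (1.93 log units; beyond the scatter).

The double bond and the group on the carbonyl changed together, so their contributions cannot be separated. A 2-(cyclopropylcarbamoyl)ethyl group and a 2-(aminocarbamoyl)ethenyl group, each changing only one of the two, would tell them apart.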